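Swapping the thioether aryl of compound 1 for a tert-butylphenyl

The source may hold more compounds than are shown below. What is called first, only, known or untested is meant among the compounds shown, and "the series" means these compounds.

Measured so far in a functional assay on HeLa cells (Homo sapiens) for inhibition, read by CCK-8 assay, with a stated time of 72 h, tested at 2 uM; a lower number here means less inhibition of growth, a higher number more inhibition of growth at the concentration tested:
compound 1, `Cc1cc(C)cc(SCc2ccc(/C=C/C(=O)Nc3ccccc3N)cc2)c1`: 11.7%
compound 2, `Nc1ccccc1NC(=O)c1ccc(CSCCc2ccccc2)cc1`: 27.7%
compound 3, `COC(=O)c1ccccc1SCc1ccc(C(=O)Nc2ccccc2N)cc1`: 29.8%

Three compounds carry the shared aminoanilide motif and have been run in this assay. Compound 1 gives 11.7%, the lowest of the three numbers. Compound 2 gives 27.7% and compound 3 gives 29.8%; both of these gaps to compound 1 are beyond the usual scatter, so compound 1 stands clearly at the bottom of the small set. For the measured compounds named here, none of the three pairs differs in a single place, so no measured step is available to guide the next change.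

The next compound, compound 4 `CC(C)(C)c1ccc(SCc2ccc(/C=C/C(=O)Nc3ccccc3N)cc2)cc1`, keeps the core of compound 1 and differs in only one place: 4-(tert-butyl)phenyl in place of 3,5-dimethylphenyl on a sulfur. The change keeps the same count of donors and acceptors and the same kind of ring, adding two carbons. Going by the values given here, with no measured step to lean on, the expectation is for a small movement, if any: the step of a number 3.3 percentage points higher from compound 1 to compound 4 (within the scatter) is expected to lie within the scatter, leaning slightly upward. Compound 4 is therefore estimated at 15%, with a range from 3% to 32%.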

Compound 4, percent growth inhibition at one concentration: 17.5%
The estimate for compound 4 lay 2.5 percentage points below the measured number; measured number inside the range.
By their numbers in this assay, from the lowest: compounds 1 and 4 (each within the scatter of the next); then compounds 2 and 3 (each within the scatter of the next).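

In this assay, for the compounds shown here, the exchange of 3,5-dimethylphenyl for 4-(tert-butyl)phenyl on a sulfur provides the first comparison in this set that differs in one place, and it reads as a number 5.8 percentage points higher from compound 1 to compound 4 (within the scatter) on the shared core. At this position, then, one aryl group of carbon only, with 8 heavy atoms, gives way to another, with 10 heavy atoms and a different arrangement of its alkyl groups, without a change in growth inhibition that can be told from the scatter. No measurement bears on why the two compounds read alike, and a single step within the scatter shows no trend at this position.

As far as these compounds go, both groups at this position are alkyl-substituted phenyl rings, so it remains open how the same place would respond to a ring carrying a carboxylic acid or an amine, or to a pyridine ring or a longer chain on the sulfur. From the compounds shown here alone, it is also open whether 4-(tert-butyl)phenyl would read the same way on the core of compound 3, where the alkene is absent.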